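Small alkoxy versus phenethyl ether: cytotoxicity notes

The source may report more compounds than this note shows. Statements on the series, on what has been measured and on what is new or still open speak of the compounds shown alone.

Values in an ADME assay on J774 cells (Mus musculus) for cytotoxicity; on this read-out higher numbers stand for an effect only at larger amounts of compound and lower numbers for an effect already at smaller amounts:
- compound 1 `CCCCc1ccc2[nH]cc(C(=O)OC)c(=O)c2c1`: > 20000 nM (a limit)
- compound 2 `COC(=O)c1c[nH]c2ccccc2c1=O`: > 20000 nM (a limit)
- compound 3 `COC(=O)c1c[nH]c2ccc(OCCc3ccccc3)cc2c1=O`: 2200 nM

Among the measured compounds shown here, compound 3, at 2200 nM, holds the only actual number. The other two values stand at the limit of > 20000 nM in this assay, at which 2 of the 3 values shown sit.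

Compound 4 `COC(=O)c1c[nH]c2ccc(OC)cc2c1=O` keeps the core of compound 3 and differs from it as follows: hydrogen in place of benzyl on a saturated chain carbon bound to an oxygen on an aromatic ring. Cut one bond further out, the same difference reads phenethyl to methyl.

For the measured compounds named here, the only measured step is a step that the two limits leave unreadable from compound 1 to compound 2, so it offers no size to carry over. Compound 2 also lacks the phenethyl group, and its value is a limit, > 20000 nM. On that basis, the expected step in this assay is an 8.2-fold higher number from compound 3 to compound 4 (0.91 log units; beyond the scatter), toward higher numbers and beyond the scatter. Compound 4 is estimated at 18000 nM, with an expected range of 6000 nM to 40000 nM. A result reported only as a limit is quite possible.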

Compound 4, half-maximal effective concentration: 6180 nM
Beside the measured number, compound 4's estimate is 2.9-fold (0.46 log units) above it, and the stated range covers the measured number.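

In this assay, the change from phenethyl to methyl gives a 2.8-fold higher number from compound 3 to compound 4 (0.45 log units; beyond the scatter), and compound 4 still returns a number rather than a limit, so a readable effect at this position does not depend on the benzyl part. Methoxy in place of hydrogen gives an at least 3.2-fold lower number from compound 2 to compound 4 (0.51 log units; beyond the scatter) and methoxy in place of butyl gives an at least 3.2-fold lower number from compound 1 to compound 4 (0.51 log units; beyond the scatter), so across these compounds the read-out does not simply follow chain length: butyl, the longer group, gives no number, whereas methoxy does. Both of these sizes are minimum values, as each step starts from a limit: the limit of > 20000 nM in this assay, at which 2 of the 4 values shown sit.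

The step between compound 1 and compound 2 cannot be read, which leaves butyl against hydrogen unresolved. Also open, from the compounds shown here alone, is whether an ethoxy group, a benzyloxy group or an ether chain ending in an amine would fall between methoxy and phenethyl.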